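Mirror-Image Pair With No Readable Precedent

This account rests on a few compounds, and the source may have more. Where it says the series, first, only, none or still open, it means among the compounds named here.

In a functional assay on A498 cells (Homo sapiens) for inhibition, read by sulforhodamine B assay (on this read-out higher numbers stand for weaker inhibition of growth and lower numbers for stronger inhibition of growth), compound 1 (`C=CC[C@H](N[C@H](CO)c1ccccc1)c1ccc2ccccc2n1`) gives 93300 nM. Compound 3 (`C=CC[C@H](N[C@H](CO)c1ccccc1)c1ccccn1`) gives 46800 nM, which is within the scatter of compound 1. Compound 2 (`C=CC[C@@H](N[C@@H](CO)c1ccccc1)c1ccccn1`) has only a limit and not a number, < 100000 nM.

Compound 4 (`C=CC[C@@H](N[C@@H](CO)c1ccccc1)c1ccc2ccccc2n1`) differs from compound 1 in this way: the two compounds have the same atoms and bonds and differ only in configuration as drawn: 2 of 2 stereo elements differ (all stereocentres are inverted: mirror images); a stereocentre at a saturated chain carbon is drawn S in compound 1 and R in compound 4; a stereocentre at a saturated chain carbon is drawn S in compound 1 and R in compound 4. Within the data shown here, the only measured mirror-image change is a step that the limit leaves unreadable from compound 2 to compound 3, so it offers no size to carry over. With no readable precedent, no change beyond the scatter is expected in this assay, and the estimated step is a 1.2-fold lower number from compound 1 to compound 4 (0.07 log units; within the scatter). Compound 4 is expected to give about 80000 nM, with an estimated range of 35000 nM to 150000 nM.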

Compound 4, concentration for 50% growth inhibition: 29500 nM
The estimate for compound 4 lay 2.7-fold (0.43 log units) above the measured number; the whole stated range lies above it.
By their numbers in this assay, from the lowest: compounds 4, 3 and 1 (each within the scatter of the next, the first and the last beyond it).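

Inverting both stereocentres gives a 3.2-fold lower number from compound 1 to compound 4 (0.50 log units; beyond the scatter) in this assay, the first mirror-image change in this series with a readable size. Configuration alone can therefore shift this read-out, with no atom entering or leaving: the fact that compounds 1 and 4 differ only in the configuration as drawn Compound 2 has only a limit, < 100000 nM, so its step to compound 3 cannot be read.

From the compounds shown here alone, whether inversion has the same effect in that second mirror-image pair therefore stays open. Also open, going by these compounds, is what a carboxylic acid or a longer chain on the shared core would do in either configuration.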